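This account rests on a few compounds, and the source may have more. Where it says the series, first, only, none or still open, it means among the compounds named here.

The measured compounds and their values in a functional assay on CHO cells for agonist activity at metabotropic glutamate receptor 5 (Homo sapiens), read by inositol phosphate accumulation; on this read-out lower numbers stand for stronger inhibition and higher numbers for weaker inhibition:
compound 1 `Cc1nc(C#Cc2cccc(Cl)c2)cs1` gives 129 nM
compound 2 `Cc1nc(C#Cc2ccc(F)cn2)cs1` gives 1090 nM
compound 3 `Cc1nc(C#Cc2ccsc2)cs1` gives 337 nM

Of these three, compound 1 stands at the lowest number in this assay, and so it is the strongest inhibitor of the set. Its nearest neighbour is compound 3, whose number is higher by more than the usual scatter of repeated measurements; compound 2 lies further off still, again beyond the scatter.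

The compound not yet measured is compound 4 `Cc1nc(C#Cc2cccc(C(N)=O)c2)cs1`. It differs from compound 1 in a single place: carbamoyl in place of chloro on an aromatic carbon. Within the data shown here, no two measured compounds differ in exactly this way, so no measured step shows directly what this exchange does. The set does show, however, that exchanging the ring substituents of compound 1 for other groups has so far only raised the number: compound 2 gives 1090 nM and compound 3 gives 337 nM. A similar outcome is expected here. Compound 4 is expected to show a step of a 6.2-fold higher number from compound 1 to compound 4 (0.79 log units; beyond the scatter), a weakening that goes beyond the scatter. Compound 4 is therefore estimated at 800 nM, within a range from 200 nM to 4000 nM.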

Compound 4, half-maximal inhibitory concentration: 1000 nM
Estimate against measurement, compound 4: 1.3-fold (0.10 log units) below, within the range that was stated.
By their numbers in this assay, from the lowest: compound 1; then compound 3; then compounds 4 and 2 (each within the scatter of the next).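

In this assay, placing carbamoyl on the aromatic carbon where compound 1 carries chloro gives a 7.8-fold higher number from compound 1 to compound 4 (0.89 log units; beyond the scatter), a step beyond the scatter. Among these compounds, this is the first reading of a single exchange at this position with the rest of the molecule held fixed: the earlier compounds differ from compound 1 in the ring itself, so they could not isolate this one carbon, whereas here the only change is that one chlorine atom gives way to a three-atom group carrying a hydrogen-bond donor and a hydrogen-bond acceptor, and inhibition is clearly weaker. No measurement shown here explains why the number rises.

The compounds shown leave open whether the weakening goes with the extra atoms or with the hydrogen-bond donor and acceptor, a question that a group such as nitrile, methyl or methoxy at this same carbon could help to separate. They also leave open how an amine or a carboxylic acid in this place would compare with chloro and carbamoyl on the same core.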